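Fluorinated benzyl variants on the shared core at orexin receptor one

The source may hold more compounds than are shown below. What is called first, only, known or untested is meant among the compounds shown, and "the series" means these compounds.

Measured so far:
compound 1 `CCc1nc(Cl)c2n1CCN([C@@H](C(=O)NC)c1ccccc1)[C@H]2COc1cccc(C(F)(F)F)c1` — 312 nM
compound 2 `CCc1nc(Cl)c2n1CCN([C@@H](C(=O)NC)c1ccccc1)[C@H]2CCc1ccc(C(F)(F)F)cc1F` — 45 nM
compound 3 `CCc1nc(Cl)c2n1CCN([C@@H](C(=O)NC)c1ccccc1)[C@H]2CCc1ccc(F)c(F)c1F` — 30 nM

In a functional assay on CHO cells for antagonist activity at Orexin/Hypocretin receptor type 1 (Homo sapiens), read by FLIPR and calcium flux (on this read-out lower numbers stand for stronger inhibition and higher numbers for weaker inhibition), compound 3 holds the lowest number of the three. Its distance from compound 1 is clear: a 10-fold lower number from compound 1 to compound 3 (1.02 log units; beyond the scatter). Its distance from compound 2 is not: a 1.5-fold lower number from compound 2 to compound 3 (0.18 log units; within the scatter), so no order between compound 2 and compound 3 is claimed.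

Compound 4 `CCc1nc(Cl)c2n1CCN([C@@H](C(=O)NC)c1ccccc1)[C@H]2CCc1cccc(C(F)(F)F)c1F` is not yet measured. It differs from compound 3 in one place: 2-fluoro-3-(trifluoromethyl)phenyl in place of 2,3,4-trifluorophenyl on a saturated chain carbon, two bonds along the chain from a saturated ring carbon. Among the compounds with values here, the only measured step that bears directly on this kind of change, one fluorinated phenyl exchanged for another on the same chain carbon, is a 1.5-fold lower number from compound 2 to compound 3 (0.18 log units; within the scatter), which stays within the scatter. The larger steps, a 6.9-fold lower number from compound 1 to compound 2 (0.84 log units; beyond the scatter) and a 10-fold lower number from compound 1 to compound 3 (1.02 log units; beyond the scatter), concern the phenoxy-to-benzyl exchange, which compound 4 keeps, so they do not argue for further movement. For compound 4 no step beyond the scatter is therefore expected: a 1.3-fold higher number from compound 3 to compound 4 (0.12 log units; within the scatter). Compound 4 is estimated at 40 nM, with a range from 15 nM to 110 nM.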

Compound 4, half-maximal inhibitory concentration: 16 nM
The estimate for compound 4 lay 2.5-fold (0.40 log units) above the measured number; low and high end bracket the measured number.
By their numbers in this assay, from the lowest: compounds 4, 3 and 2 (each within the scatter of the next, the first and the last beyond it); then compound 1.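

Within the data shown here, with the 2-fluoro kept, 2-fluoro-3-(trifluoromethyl)phenyl in place of 2-fluoro-4-(trifluoromethyl)phenyl gives in this assay a 2.8-fold lower number from compound 2 to compound 4 (0.45 log units; beyond the scatter), the first exchange of one fluorinated phenyl for another to lie beyond the scatter, so the site of the trifluoromethyl group on this ring registers in the read-out for this pair. Against 2,3,4-trifluorophenyl the same group gives a 1.9-fold lower number from compound 3 to compound 4 (0.27 log units; within the scatter), which sets no order, while against the 3-(trifluoromethyl)phenoxy group of compound 1 the step is a 20-fold lower number from compound 1 to compound 4 (1.29 log units; beyond the scatter). No measurement at hand gives a reason for these differences.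

The compounds shown leave open how the 3-(trifluoromethyl)phenyl group behaves without the 2-fluoro. They also leave open whether an amine or a carboxylic acid on this ring, or a longer chain at this place, would be tolerated.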